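Swapping the Amide Aryl Group: Methoxyphenyl to Furan

The source may report more compounds than this note shows. Statements on the series, on what has been measured and on what is new or still open speak of the compounds shown alone.

Compound 2 `COc1ccc(C(=O)N(C)c2ccc3[nH]c(-c4n[nH]c5ccccc45)cc3n2)cc1` carries a 4-methoxyphenyl group on the carbonyl carbon of its amide. In a functional assay on SMMC-7721 cells (Homo sapiens) for antiproliferative activity, read by MTT assay, with a stated time of 72 h (on this read-out lower numbers stand for stronger inhibition and higher numbers for weaker inhibition), compound 2 gives 23700 nM, and its only measured companion, compound 1 `CC(=O)N(C)c1ccc2[nH]c(-c3n[nH]c4ccccc34)cc2n1`, gives 23400 nM; the two numbers sit within the scatter of each other, as the step of a 1.0-fold higher number from compound 1 to compound 2 (0.01 log units; within the scatter) shows. Compound 3 `CN(C(=O)c1ccco1)c1ccc2[nH]c(-c3n[nH]c4ccccc34)cc2n1` differs from compound 2 by furan-2-yl in place of 4-methoxyphenyl on a carbonyl carbon. For the measured compounds named here, because the one comparable step a 1.0-fold higher number from compound 1 to compound 2 (0.01 log units; within the scatter) was flat even for a much larger change, little movement is expected: a 1.0-fold lower number from compound 2 to compound 3 (0.01 log units; within the scatter). Compound 3 is therefore estimated at 23000 nM, within a range from 10000 nM to 55000 nM.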

Compound 3, half-maximal inhibitory concentration: 28200 nM
For compound 3 the middle estimate is 1.2-fold (0.09 log units) below the measured one; low and high end bracket the measured number.
By their numbers in this assay, from the lowest: compounds 1, 2 and 3 (each within the scatter of the next).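

With a five-membered aromatic ring on the carbonyl carbon, the result in this assay remains within the scatter: a 1.2-fold higher number from compound 2 to compound 3 (0.08 log units; within the scatter), and a 1.2-fold higher number from compound 1 to compound 3 (0.08 log units; within the scatter). These numbers therefore do not tell methyl, 4-methoxyphenyl and furan-2-yl apart at this place. No measurement available here gives a reason for this. On these data alone, it remains open whether a different kind of group on this carbonyl carbon, such as an amine or a carboxylic acid, would change the number. As far as these compounds go, the effect of changes elsewhere on the shared core also remains open.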